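The compounds below may be only part of what the source reports. "The series", "measured", "known", "first", "only" and "open" are said of these compounds alone.

Of the compounds shown here, three share one core and have so far been measured in an assay on isolated protein for inhibition of cathepsin S (Homo sapiens), read by fluorescence, with a stated time of 20 min; on this read-out higher numbers stand for weaker inhibition and lower numbers for stronger inhibition. Compound 1 `CC(C)(C#N)NC(=O)[C@@H]1C[C@@H](S(=O)(=O)c2ccccc2)C[C@H]1C(=O)N1CCOCC1` gives 3 nM. Compound 2 `N#CC1(NC(=O)[C@@H]2C[C@@H](S(=O)(=O)c3ccccc3)C[C@H]2C(=O)N2CCOCC2)CC1` gives 0.7 nM, and compound 3 `N#CC1(NC(=O)[C@@H]2C[C@@H](S(=O)(=O)c3ccccc3)C[C@H]2C(=O)N2CCOCC2)CCC1` gives 4 nM. Compound 2 thus has the lowest number of the three: the step of a 4.3-fold lower number from compound 1 to compound 2 (0.63 log units; beyond the scatter) and the step of a 5.7-fold higher number from compound 2 to compound 3 (0.76 log units; beyond the scatter) both lie beyond the scatter, whereas the step of a 1.3-fold higher number from compound 1 to compound 3 (0.12 log units; within the scatter) does not.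

Compound 4 `N#CC1(NC(=O)[C@@H]2C[C@@H](S(=O)(=O)c3ccccc3)C[C@H]2C(=O)N2CC3(COC3)C2)CC1` has not yet been measured. It differs from compound 2 in one place: a group of 7 heavy atoms (5 carbon, 1 nitrogen, 1 oxygen; 2 four-membered non-aromatic rings with 1 hetero atom each) in place of a group of 6 heavy atoms (4 carbon, 1 nitrogen, 1 oxygen; one six-membered non-aromatic ring with 2 hetero atoms), on a carbonyl carbon. Among the measured compounds shown here, all three measured steps concern the group on the amide-type nitrogen; none touches the carbonyl carbon where the new group sits, so no measured step bears directly on this change. The morpholin-4-yl group is the same in compounds 1, 2 and 3, so nothing yet shows how this assay answers to a change at that position. With no measured guide, the plain expectation for compound 4 is a step of a 1.7-fold higher number from compound 2 to compound 4 (0.23 log units; within the scatter) that may well fall within the scatter. The estimate for compound 4 in this assay is therefore 1.2 nM, with a range from 0.4 nM to 4 nM.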

Compound 4, half-maximal inhibitory concentration: 3 nM
For compound 4 the middle estimate is 2.5-fold (0.40 log units) below the measured one, and the stated range covers the measured number.
By their numbers in this assay, from the lowest: compound 2; then compounds 1, 4 and 3 (each within the scatter of the next).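

Among the compounds shown here, compound 4 gives the first view of a change at the group on the carbonyl carbon, and in this assay this position proves to matter: replacing morpholin-4-yl with the group of two four-membered rings gives a 4.3-fold higher number from compound 2 to compound 4 (0.63 log units; beyond the scatter) and so moves the number beyond the usual scatter. This step is as large as a 4.3-fold lower number from compound 1 to compound 2 (0.63 log units; beyond the scatter) at the amide-type nitrogen, but it runs towards a higher number, so changes at either place can shift inhibition to a similar extent. The entering group has the same counts of hydrogen-bond donors and acceptors as morpholin-4-yl and no net charge, so these counts do not separate the two groups, and no measurement here explains the higher number.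

From the compounds shown here alone, with one change at this position, it remains open whether a piperidin-1-yl group, which has no ring oxygen, or a simple dimethylamino group would give a number closer to that of compound 2 or of compound 4. Going by these compounds, it is also open whether the same exchange would give a similar step with the 1-cyano-1-methylethyl group of compound 1 or the 1-cyanocyclobutyl group of compound 3 on the amide-type nitrogen.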